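Adding a methoxy group to the phenyl arm of compound 3

A few compounds are considered here, and "the series" means these few. Any claim that something is new, unique, unknown or untested is made for them only; others in the source may bear on it.

Of the compounds shown here, three sharing one core have been measured in a functional assay on HeLa cells (Homo sapiens) for inhibition, read by CCK-8 assay, with a stated time of 48 h; a lower number here means a stronger inhibitor, a higher number a weaker inhibitor. Compound 1 `COc1cc(-c2ccnc3cc(-c4ccc(C(C)=O)cc4)nn23)cc(OC)c1OC` gives 1810 nM, compound 2 `COc1ccc(-c2cc3nccc(-c4cc(OC)c(OC)c(OC)c4)n3n2)cc1F` gives 236 nM, and compound 3 `COc1cc(-c2ccnc3cc(-c4ccccc4)nn23)cc(OC)c1OC` gives 458 nM. Among these three numbers compound 3 stands second highest: its nearest neighbour is compound 2, with the step of a 1.9-fold higher number from compound 2 to compound 3 (0.29 log units; within the scatter) lying within the scatter, while a 4.0-fold lower number from compound 1 to compound 3 (0.60 log units; beyond the scatter) separates it clearly from compound 1. The unmeasured compound 4 `COc1ccc(-c2cc3nccc(-c4cc(OC)c(OC)c(OC)c4)n3n2)cc1` differs from compound 3 by methoxy in place of hydrogen on an aromatic carbon, placed on an aromatic carbon of a six-membered aromatic ring of carbon only, para to a large group. The step that bears on this change most directly is a 1.9-fold higher number from compound 2 to compound 3 (0.29 log units; within the scatter), in which a phenyl replaced a 3-fluoro-4-methoxyphenyl and the number shifted only within the scatter; a 7.7-fold lower number from compound 1 to compound 2 (0.88 log units; beyond the scatter) also involves this arm but removes an acetyl at the same time, so it speaks less directly. The expected step is therefore small and directed toward a lower number, a 1.5-fold lower number from compound 3 to compound 4 (0.18 log units; within the scatter), and compound 4 is estimated at 300 nM, with a range of 120 nM to 750 nM.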

Compound 4, half-maximal inhibitory concentration: 373 nM
Estimate against measurement, compound 4: 1.2-fold (0.09 log units) below; the range from low to high includes it.
By their numbers in this assay, from the lowest: compounds 2, 4 and 3 (each within the scatter of the next); then compound 1.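

In this assay, methoxy on the phenyl arm, para to a large group, gives a 1.2-fold lower number from compound 3 to compound 4 (0.09 log units; within the scatter), so this group alone does not move the number beyond the scatter. Removing the fluoro from the 3-fluoro-4-methoxyphenyl arm gives a 1.6-fold higher number from compound 2 to compound 4 (0.20 log units; within the scatter), so that group also has no separable effect here, while methoxy in place of acetyl gives a 4.9-fold lower number from compound 1 to compound 4 (0.69 log units; beyond the scatter), leaving acetyl as the only arm substituent shown that stands apart from hydrogen, methoxy and the fluoro-methoxy pair. Nothing measured here accounts for these results.

On these data alone, whether a hydroxyl, an amine or a carboxylic acid at this place would read like methoxy or like acetyl remains open. So does whether a longer chain, such as ethoxy, would keep the number within the scatter of methoxy.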